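A few compounds are considered here, and "the series" means these few. Any claim that something is new, unique, unknown or untested is made for them only; others in the source may bear on it.

Measured compounds:
- compound 1, `O=CN1N=C(c2ccc(Cl)cc2)CC1c1cn(-c2ccccc2)nc1-c1ccc(Cl)c(Cl)c1`, giving 35.1% in a functional assay on the whole organism (strain Wistar) for inhibition, with Rattus norvegicus as the target, read by paw edema, with a stated time of 30 min, at a dose of 50 mg/kg by the oral route; on this read-out higher numbers stand for more inhibition at the one dose given (going by the name of the read-out) and lower numbers for less inhibition
- compound 2, `Clc1ccc(C2=NNC(c3cn(-c4ccccc4)nc3-c3ccc(Cl)c(Cl)c3)C2)cc1`, giving 33% in this assay

Within the data shown here, only two compounds have numbers so far. Among the measured compounds shown here, compound 2 and compound 1 lie within the scatter of each other, so the inhibition in this assay can only be called level between the two; the one measured step, a number 2.1 percentage points lower from compound 1 to compound 2 (within the scatter), shows that replacing the formyl group on the ring amine nitrogen by hydrogen changed nothing beyond the scatter.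

Compound 3, `O=[N+]([O-])c1ccc(N2N=C(c3ccc(Cl)cc3)CC2c2cn(-c3ccccc3)nc2-c2ccc(Cl)c(Cl)c2)cc1`, is not yet measured. It is made from compound 2 by the change (4-nitrophenyl in place of hydrogen on an amine nitrogen in a ring). For the measured compounds named here, the only step that bears on this change is the one at the same ring nitrogen, a number 2.1 percentage points lower from compound 1 to compound 2 (within the scatter), which was small; it involved a much smaller group than 4-nitrophenyl, so it is a weak guide. With nothing else to go on, no step beyond the scatter is expected, and the value of compound 3 is estimated as 38%, with a range from 20% to 56%, which means an expected step of a number 5 percentage points higher from compound 2 to compound 3 (within the scatter).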

Compound 3, a percentage reported as inhibition, in the whole organism at one dose (the size of the read-out at that dose, not a potency): 48.9%
The estimate for compound 3 lay 10.9 percentage points below the measured number, within the range that was stated.
By their numbers in this assay, from the lowest: compounds 2 and 1 (each within the scatter of the next); then compound 3.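

So far the amine nitrogen in the ring had looked indifferent to what it carries, since swapping formyl for hydrogen there left this assay level within the scatter. The 4-nitrophenyl group shows that this position can respond: it gives a number 15.9 percentage points higher from compound 2 to compound 3 (beyond the scatter) when it replaces hydrogen and a number 13.8 percentage points higher from compound 1 to compound 3 (beyond the scatter) when it replaces formyl, both modest but clear of the noise, so the gain holds against either of the two smaller groups. Nothing available here says what lies behind this gain.

The compounds shown leave open whether the gain comes from the six-membered aromatic ring itself or from the nitro group it carries, and a plain phenyl or a 4-aminophenyl on the same nitrogen would begin to separate the two. From the compounds shown here alone, it also remains open whether the ring must sit directly on the nitrogen, which a benzyl group, with one carbon between the two, would test, and each number here describes a single dose rather than a potency.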